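The source may report more compounds than this note shows. Statements on the series, on what has been measured and on what is new or still open speak of the compounds shown alone.

Measured so far in a functional assay on EBC-1 cells (Homo sapiens) for antiproliferative activity, with a stated time of 72 h; a lower number here means a stronger inhibitor, a higher number a weaker inhibitor:
compound 1, `OCCn1cc(-c2cc(F)c3ncc(Cc4ccc5ncccc5c4)n3c2)cn1`: 0.34 nM
compound 2, `N#Cc1cccc(-c2cc(F)c3ncc(Cc4ccc5ncccc5c4)n3c2)c1`: 107 nM
compound 3, `N#Cc1ccc(-c2cc(F)c3ncc(Cc4ccc5ncccc5c4)n3c2)cc1F`: 145 nM

Compound 3 gives the highest number of the three; its gap to compound 2 is within the scatter, whereas the gap to compound 1 is large, as a 430-fold higher number from compound 1 to compound 3 (2.63 log units; beyond the scatter) shows. The parallel step a 310-fold higher number from compound 1 to compound 2 (2.50 log units; beyond the scatter) is of the same order, and a 1.4-fold higher number from compound 2 to compound 3 (0.13 log units; within the scatter) adds little.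

Compound 4, `O=C(NCc1cc(F)cc(F)c1)c1ccc(-c2cc(F)c3ncc(Cc4ccc5ncccc5c4)n3c2)cc1F`, differs from compound 3 in one place: (3,5-difluorobenzyl)carbamoyl in place of cyano on an aromatic carbon. Within the data shown here, none of the measured steps touches this position in this way; the only change at the cyano-bearing ring, a 1.4-fold higher number from compound 2 to compound 3 (0.13 log units; within the scatter), concerned a fluoro group and stayed within the scatter. The step to compound 4 is therefore uncharted, with a much larger group entering than any exchanged so far among compounds 1 to 3.

For compound 4 in this assay a number in the region of compound 3 is expected, with a wide range: 60 nM (10 nM to 400 nM), corresponding to an expected 2.4-fold lower number from compound 3 to compound 4 (0.38 log units; beyond the scatter).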

Compound 4, half-maximal inhibitory concentration: 53.6 nM
Beside the measured number, compound 4's estimate is 1.1-fold (0.05 log units) above it; measured number inside the range.
By their numbers in this assay, from the lowest: compound 1; then compounds 4, 2 and 3 (each within the scatter of the next, the first and the last beyond it).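

The position ortho to a fluoro group tolerates a far larger substituent than cyano: in this assay, (3,5-difluorobenzyl)carbamoyl, with 12 heavy atoms, one aromatic ring and 1 hydrogen-bond donor, replaces a 2-heavy-atom group and gives a 2.7-fold lower number from compound 3 to compound 4 (0.43 log units; beyond the scatter) as a modest change. Among these compounds, compounds 1 to 3 could not show this, as their only change on this ring stayed within the scatter and involved a fluoro group, not the cyano position. Nothing measured here accounts for the shift.

Whether the amide hydrogen, the benzyl ring or its two fluoro groups carries the step stays open, since this single large group is the only replacement shown. Also open, on these data alone, is whether a primary amide, a carboxylic acid or an unsubstituted benzyl amide here would move the number towards compound 1 at 0.34 nM or leave it unchanged.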